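This account rests on a few compounds, and the source may have more. Where it says the series, first, only, none or still open, it means among the compounds named here.

Measured so far:
compound 1 `CCC(=O)c1ccc2c(c1)sc(=O)n2CCCCCN1CCCCCC1` — 12.2 nM
compound 2 `CCC(=O)c1ccc2c(c1)sc(=O)n2CCCCCCN1CCCCCC1` — 10.4 nM
compound 3 `CCCc1ccc2c(c1)sc(=O)n2CCCCN1CCCCCC1` — 6.1 nM

All three values come from an assay on cell membranes for displacement of a labelled ligand from Sigma non-opioid intracellular receptor 1 (Rattus norvegicus); a lower number here means a stronger inhibitor, a higher number a weaker inhibitor. Within that set, a 1.2-fold lower number from compound 1 to compound 2 (0.07 log units; within the scatter), the change being ((azepan-1-yl)methyl in place of azepan-1-yl on a saturated chain carbon, five bonds along the chain from an aromatic nitrogen). Compound 3 and compound 1 differ in more than one place; the difference between the two cores is not broken down here. Compound 4 `CCCc1ccc2c(c1)sc(=O)n2CCCCCN1CCCCCC1` is not yet measured in this assay. It carries the same kind of change as the earlier step, ((azepan-1-yl)methyl in place of azepan-1-yl on a saturated chain carbon, four bonds along the chain from an aromatic nitrogen), but on a saturated chain carbon four bonds along the chain from an aromatic nitrogen, not five bonds as before. The expected step for compound 4 is a 1.1-fold lower number from compound 3 to compound 4 (0.04 log units; within the scatter), resting on compound 1 to compound 2 giving a 1.2-fold lower number from compound 1 to compound 2 (0.07 log units; within the scatter) and on compound 3 giving 6.1 nM. Compound 4 is estimated at 5.5 nM, within 2.5 nM to 12 nM.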

Compound 4, inhibition constant: 4.6 nM
For compound 4 the middle estimate is 1.2-fold (0.08 log units) above the measured one; the range from low to high includes it.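

In this assay, (azepan-1-yl)methyl in place of azepan-1-yl gives a 1.3-fold lower number from compound 3 to compound 4 (0.12 log units; within the scatter) on the propyl core, and the step carries across the two cores without a measurable difference: the same change on two cores in this assay, a 1.2-fold lower number (0.07 log units; within the scatter) from compound 1 to compound 2 and a 1.3-fold lower number (0.12 log units; within the scatter) from compound 3 to compound 4, 1.1-fold (0.05 log units) apart, within the scatter of two such steps. Both steps lie within the scatter, so the two cores agree only in showing no clear effect of this change; neither step shows how the change would behave on any other core. Propyl in place of propanoyl on an aromatic carbon gives a 2.7-fold lower number from compound 1 to compound 4 (0.42 log units; beyond the scatter), a modest step beyond the scatter, but it is read only once, on a single chain.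

On these data alone, whether that step holds on other chains remains open. Also open, as far as these compounds go, is how a piperidine or morpholine ring in place of azepan-1-yl would read.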